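This account rests on a few compounds, and the source may have more. Where it says the series, first, only, none or still open, it means among the compounds named here.

The measured compounds:

Compound 1, `O=C(/C=C/c1ccc([N+](=O)[O-])cc1)Nc1cc(Sc2ncn[nH]2)c(O)c2ccccc12`: in a functional assay on MDA-MB-231 cells (Homo sapiens) for antiproliferative activity, read by MTT assay, with a stated time of 48 h (a higher number here means a weaker inhibitor, a lower number a stronger inhibitor), compound 1 gives only a limit, > 100000 nM.
Compound 2, `O=C(Nc1cc(Sc2ncn[nH]2)c(O)c2ccccc12)c1cccc(Cl)c1`: in this assay compound 2 likewise gives only a limit, > 100000 nM.
Compound 3, `O=C(Nc1cc(Sc2ncnc3nc[nH]c23)c(O)c2ccccc12)c1ccc([N+](=O)[O-])cc1`: in this assay compound 3 also gives only a limit, > 100000 nM.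

Compound 2 therefore stands at the limit of this assay, and so do the other two values shown (the limit of > 100000 nM in this assay, at which 3 of the 3 values shown sit). Among the measured compounds shown here, no measured pair differs in one place, so no step size is known from these three.

Compound 4, `O=C(Nc1cc(Sc2ncn[nH]2)c(O)c2ccccc12)c1ccc2ccccc2c1`, is the untested partner of compound 2. It differs by naphthalen-2-yl in place of 3-chlorophenyl on a carbonyl carbon. For the measured compounds named here, since every value so far sits at the limit, no step beyond the scatter can be expected in either direction, and the most that can be said is that compound 4 is expected to stay where compound 2 stands, with a number no higher from compound 2 to compound 4 (the limit leaves the size open). For compound 4 the estimate in this assay is 100000 nM, with a range from 30000 nM to 300000 nM.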

Compound 4, half-maximal inhibitory concentration: 45100 nM
Beside the measured number, compound 4's estimate is 2.2-fold (0.35 log units) above it, and the stated range covers the measured number.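

Among the values shown, compound 4 is the only one that falls inside the measurable range of this assay, so this position on the carbonyl carbon can move the read-out off the limit. Naphthalen-2-yl in place of 3-chlorophenyl gives an at least 2.2-fold lower number from compound 2 to compound 4 (0.34 log units; beyond the scatter). That step has a lower bound only, and its full size stays unknown: the limit of > 100000 nM in this assay, at which 3 of the 4 values shown sit.

The change adds a second six-membered aromatic ring and removes the chlorine at once, so the compounds shown do not tell which of the two matters, or whether a phenyl group without chlorine would behave like either. From the compounds shown here alone, how an amine, a carboxylic acid or a longer alkyl chain on this carbonyl carbon would read in this assay also remains open.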